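Three limits and one new amide group

A few compounds are considered here, and "the series" means these few. Any claim that something is new, unique, unknown or untested is made for them only; others in the source may bear on it.

Going by the values given here, in an ADME assay on MT4 cells (Homo sapiens) for cytotoxicity, read by MTT assay (a higher number here means that more compound is tolerated, a lower number that less compound is tolerated), every measured compound so far stops at a limit, so no plain number exists yet. Compound 1 (`Cc1cc(C)cc(S(=O)(=O)c2c(C(=O)NCc3cccc(F)c3F)[nH]c3ccc(Cl)cc23)c1`) gives > 51100 nM as a limit of the assay. Compound 2 (`Cc1cc(C)cc(S(=O)(=O)c2c(C(=O)NCC(=O)NCc3ccco3)[nH]c3ccc(Cl)cc23)c1`) gives > 50000 nM as a limit too. Compound 3 (`Cc1cc(C)cc(S(=O)(=O)c2c(C(=O)NCc3n[nH]c4ccccc34)[nH]c3ccc(Cl)cc23)c1`) gives > 50700 nM as a limit as well, and this is the starting point here.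

Among the compounds with values here, compound 4 (`Cc1cc(C)cc(S(=O)(=O)c2c(C(=O)Nc3cc(C#N)ccn3)[nH]c3ccc(Cl)cc23)c1`) keeps the shared core but carries 4-cyanopyridin-2-yl in place of (1H-indazol-3-yl)methyl on an amide-type nitrogen as its only change.

Within the data shown here, three measured steps bear on this swap. The steps a step that the two limits leave unreadable from compound 1 to compound 2 and a step that the two limits leave unreadable from compound 1 to compound 3 and a step that the two limits leave unreadable from compound 2 to compound 3 each exchanged a group on a saturated chain carbon bound to an amide-type nitrogen, and none of them has a readable size. On that thin basis no step beyond the usual scatter is expected in this assay and the estimated change is an at least 1.0-fold lower number from compound 3 to compound 4 (0.00 log units; that floor lies within the scatter) in this reading. The estimated value for compound 4 is 50000 nM with a range expected from 15000 nM up to 60000 nM and a good chance of another limit.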

Compound 4, half-maximal cytotoxic concentration: > 53700 nM
Compound 4: only a limit was reported; the forecaster's own chance of this, stated with the estimate: 75%; middle value at least 1.0-fold (0.03 log units) from the limit.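

In this assay compound 4 gives > 53700 nM, again a limit of the assay and not a number. The steps linking compound 4 with compound 1, compound 2 and compound 3 therefore cannot be read. The compounds shown leave open at what concentration any of them harms these cells, and whether exchanging these groups changes that concentration.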